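Cytotoxicity of a Benzoxazole Analogue: A Limit Expected

This account rests on a few compounds, and the source may have more. Where it says the series, first, only, none or still open, it means among the compounds named here.

Four compounds share one core and differ only in the aromatic group attached to one carbon of that core. Compound 1 `Nc1nc(Cl)c(-c2ccccn2)c(N[C@@H]2C[C@H](CO)[C@@H](O)[C@H]2O)n1` carries pyridin-2-yl, compound 2 `Nc1nc(Cl)c(-c2ccco2)c(N[C@@H]2C[C@H](CO)[C@@H](O)[C@H]2O)n1` carries furan-2-yl, and compound 3 `Nc1nc(Cl)c(-c2ncco2)c(N[C@@H]2C[C@H](CO)[C@@H](O)[C@H]2O)n1` carries 1,3-oxazol-2-yl. In an ADME assay on cells (Homo sapiens) for cytotoxicity, read by polymerase chain reaction, with a stated time of 3 days (on this read-out higher numbers stand for lower toxicity in this test and lower numbers for higher toxicity in this test), compound 1 reaches only a limit of the assay, > 25000 nM. Compound 2 likewise gives only a limit, > 25000 nM. Compound 3 too gives only a limit, > 25000 nM. So compound 3 stands exactly where the other measured compounds stand, at the limit of > 25000 nM in this assay, at which 3 of the 3 values shown sit, with no number of its own. The steps between the measured compounds, a step that the two limits leave unreadable from compound 1 to compound 2, a step that the two limits leave unreadable from compound 1 to compound 3 and a step that the two limits leave unreadable from compound 2 to compound 3, all run from one limit to another, and none has a readable size. Compound 4 `Nc1nc(Cl)c(-c2nc3ccccc3o2)c(N[C@@H]2C[C@H](CO)[C@@H](O)[C@H]2O)n1` differs from compound 3 by 1,3-benzoxazol-2-yl in place of 1,3-oxazol-2-yl on an aromatic carbon. Within the data shown here, all three measured steps bear on this change, as each also swaps the aromatic group in the same place, and all three are unreadable; no step of readable size is therefore expected, and compound 4 is expected to sit at the limit as well. The expected step is a number no higher from compound 3 to compound 4 (the limit leaves the size open). Compound 4 is estimated at 25000 nM, with a range from 10000 nM to 60000 nM.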

Compound 4, half-maximal cytotoxic concentration: 12000 nM
The estimate for compound 4 lay 2.1-fold (0.32 log units) above the measured number, within the range that was stated.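

At this position, on the aromatic carbon ortho to a chloro group and para to an amino group, the choice of aromatic group can move the read-out of this assay off its limit: replacing 1,3-oxazol-2-yl with 1,3-benzoxazol-2-yl, which brings in one six-membered aromatic ring of carbon only, gives an at least 2.0-fold lower number from compound 3 to compound 4 (0.31 log units; beyond the scatter). The same group also stands apart from the other two aromatic groups, with an at least 2.0-fold lower number from compound 2 to compound 4 (0.31 log units; beyond the scatter) and with an at least 2.0-fold lower number from compound 1 to compound 4 (0.31 log units; beyond the scatter), and on this read-out a lower number stands for higher toxicity in this test. The steps among the other three compounds still cannot be read, and those compounds remain at a limit: the limit of > 25000 nM in this assay, at which 3 of the 4 values shown sit.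

As far as these compounds go, each of the three limits hides a true number, so how large these steps really are stays open. Also open, from the compounds shown here alone, is whether the added carbon ring alone accounts for the change, and how a plain phenyl group, a 1,3-benzothiazol-2-yl group or an amine on this same carbon would read in this assay.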